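Methyl in Place of Chloro and Metabolic Stability

A few compounds are considered here, and "the series" means these few. Any claim that something is new, unique, unknown or untested is made for them only; others in the source may bear on it.

Compound 1 `CC(=O)Nc1cc(-c2ccc(OC[C@@H](N)CC(C)C)c(C)c2)ccn1`: 91%
Compound 2 `CC(=O)Nc1cc(-c2ccc(OC[C@@H](N)CC(C)C)c(Cl)c2)ccn1`: 89%
Compound 3 `Cc1cc(-c2cc(Cl)c(OC[C@@](C)(N)CC(C)C)cn2)ccn1`: 86%

All three were measured in an ADME assay on microsomes from liver (Homo sapiens) for metabolic stability, read by LC-MS, using NADPH, with a stated time of 10 min, tested at 0.5 uM (a higher number here means that more of the compound is left, a lower number that less of the compound is left), and each leaves most of the compound intact. Compound 2 and compound 1 differ by methyl in place of chloro on an aromatic carbon, and that change gave a number 2 percentage points higher from compound 2 to compound 1 (within the scatter). Compound 3 shares the amine-bearing side chain but has another core; the difference between the two cores is not broken down here. Its value sits close to those of compound 1 and compound 2.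

Compound 4 `Cc1cc(-c2cc(C)c(OC[C@@](C)(N)CC(C)C)cn2)ccn1` is not yet measured. It differs from compound 3 by methyl in place of chloro on an aromatic carbon. This is the same kind of change as from compound 2 to compound 1, but the surroundings differ: here the ring is a six-membered aromatic ring with 1 nitrogen, ortho to a group of 9 heavy atoms, meta to a 2-methylpyridin-4-yl group and opposite the ring nitrogen, whereas before it was a ring of carbon only, ortho to a (2-amino-4-methylpentyl)oxy group and meta to a large group.

Because a number 2 percentage points higher from compound 2 to compound 1 (within the scatter) stayed within the scatter, compound 4 is expected to show a step of a number 2 percentage points higher from compound 3 to compound 4 (within the scatter). Compound 4 is estimated at 88%, between 78% and 96%.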

Compound 4, percent of the compound remaining: 79%
Estimate against measurement, compound 4: 9 percentage points above, and the stated range covers the measured number.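

In this assay methyl in place of chloro gave a number 7 percentage points lower from compound 3 to compound 4 (within the scatter) on the second core, and this step, like the earlier one, stays within the usual scatter of repeated measurements. Within the data shown here, this does not show that the change acts identically on both cores: there is only one pair for each core, and a real difference smaller than the scatter would stay hidden. What can be said is narrower, namely that the two steps cannot be told apart: the same change on two cores in this assay, a number 2 percentage points higher (within the scatter) from compound 2 to compound 1 and a number 7 percentage points lower (within the scatter) from compound 3 to compound 4, 9 percentage points apart, within the scatter of two such steps

The compounds shown leave open whether other groups at this place on the ring, such as fluoro, methoxy or nitrile, would behave like methyl and chloro. They also leave open whether the swap would give a similar step on a third core, since two cores are too few to show how well it carries across the wider series.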